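Carboxy for dimethylsulfamoyl: microsomal clearance notes

This account rests on a few compounds, and the source may have more. Where it says the series, first, only, none or still open, it means among the compounds named here.

Measured so far:
compound 1 `COc1ccc(-c2cc(-c3ccc(S(=O)(=O)N(C)C)cc3)cnc2N)cn1`: 98.8 mL.min-1.g-1
compound 2 `COc1ccc(-c2cc(-c3ccc(S(C)(=O)=O)cc3C(F)(F)F)cnc2N)cn1`: < 7 mL.min-1.g-1

For the measured compounds named here, in an in vitro ADME assay on microsomes from liver (Homo sapiens) for metabolic stability (a higher number here means faster removal of the compound, a lower number slower removal), compound 1 gives 98.8 mL.min-1.g-1, the only number recorded in this set. Compound 2 returns < 7 mL.min-1.g-1, which is a limit of the assay and not a number; it is the compound sitting at the limit of < 7 mL.min-1.g-1 in this assay, at which 1 of the 2 values shown sits. Going by the values given here, no step between the two measured compounds is computed, since they differ in more than one place.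

Compound 3 `COc1ccc(-c2cc(-c3ccc(C(=O)O)cc3)cnc2N)cn1` is not yet measured. It differs from compound 1 by carboxy in place of dimethylsulfamoyl on an aromatic carbon. Among the compounds with values here, no measured step covers a change of this kind, so the expectation rests on the structural change alone. The expected step is a 6.6-fold lower number from compound 1 to compound 3 (0.82 log units; beyond the scatter), downward and beyond the usual scatter. For compound 3 the estimate in this assay is 15 mL.min-1.g-1, with a range from 7 mL.min-1.g-1 to 50 mL.min-1.g-1, and a fair chance that only a limit is reported.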

Compound 3, intrinsic clearance in microsomes: < 7 mL.min-1.g-1
Compound 3 ended at the assay's limit; the forecaster's own chance of this, stated with the estimate: 35%; middle value at least 2.1-fold (0.33 log units) away from the limit.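

Unlike compound 2, which differs from compound 1 in more than one place, compound 3 ties a change in this assay to this one aromatic carbon, para to a large group: carboxy in place of dimethylsulfamoyl gives an at least 14-fold lower number from compound 1 to compound 3 (1.14 log units; beyond the scatter). Compound 3 gives < 7 mL.min-1.g-1, which is a limit of the assay and not a number. With the rest of the structure unchanged, this single exchange is enough to reach the lower end of the read-out: the limit of < 7 mL.min-1.g-1 in this assay, at which 2 of the 3 values shown sit.

From the compounds shown here alone, how far compound 3 lies past that limit remains unknown, and so does the full size of the step. The compounds shown also cannot separate the loss of dimethylsulfamoyl from the gain of carboxy, and a primary amide or a tetrazole on the same carbon would bear on that question.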